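This account rests on a few compounds, and the source may have more. Where it says the series, first, only, none or still open, it means among the compounds named here.

Of the compounds shown here, three that share one core have been measured in a functional assay on MCF7 cells (Homo sapiens) for antiproliferative activity; a higher number here means a weaker inhibitor, a lower number a stronger inhibitor. Compound 1 `COc1cc(Cc2nc3c(N)ncnc3n2CC2CCCO2)cc(OC)c1OC` gives 91200 nM. Compound 2 `COc1cc(Cc2nc3c(N)ncnc3n2CCCC(C)C)cc(OC)c1OC` gives 69200 nM, and compound 3 `CCn1c(Cc2cc(OC)c(OC)c(OC)c2)nc2c(N)ncnc21` gives 79400 nM. On these three numbers compound 3 stands second highest, with compound 2 as its nearest neighbour and compound 1 as its furthest; the step of a 1.1-fold higher number from compound 2 to compound 3 (0.06 log units; within the scatter) and the step of a 1.1-fold lower number from compound 1 to compound 3 (0.06 log units; within the scatter) both lie within the scatter, as does the step of a 1.3-fold lower number from compound 1 to compound 2 (0.12 log units; within the scatter).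

Compound 4 `CCC(C)Cn1c(Cc2cc(OC)c(OC)c(OC)c2)nc2c(N)ncnc21` is the next compound, and it differs from compound 3 by sec-butyl in place of methyl on a saturated chain carbon bound to an aromatic nitrogen. All three measured steps concern the same place on the chain that carries the aromatic nitrogen, exchanging oxolan-2-yl, isopentyl, methyl and hydrogen against one another, and none of them moves the number beyond the scatter. The exchange of methyl for sec-butyl at that place is therefore expected to give no step beyond the scatter, a 1.1-fold lower number from compound 3 to compound 4 (0.04 log units; within the scatter). Compound 4 is estimated at 72000 nM, with a range from 30000 nM to 170000 nM.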

Compound 4, half-maximal inhibitory concentration: 61700 nM
Beside the measured number, compound 4's estimate is 1.2-fold (0.07 log units) above it, within the range that was stated.
By their numbers in this assay, from the lowest: compounds 4, 2, 3 and 1 (each within the scatter of the next).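

In this assay, sec-butyl on a saturated chain carbon bound to an aromatic nitrogen leaves the number within the scatter of every earlier group, with a 1.3-fold lower number from compound 3 to compound 4 (0.11 log units; within the scatter) against methyl, a 1.1-fold lower number from compound 2 to compound 4 (0.05 log units; within the scatter) against isopentyl and a 1.5-fold lower number from compound 1 to compound 4 (0.17 log units; within the scatter) against oxolan-2-yl. The last of these is the widest step yet seen in the set, but it too stays within the scatter, so the read-out does not separate these four groups at this place, whether the group carries a ring or not. Nothing available explains this flat response.

As far as these compounds go, it remains open whether an amine or a carboxylic acid at this place would move the number beyond the scatter. All four compounds share the rest of their structure, so they also leave open what a change elsewhere on the shared core would do.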